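A few compounds are considered here, and "the series" means these few. Any claim that something is new, unique, unknown or untested is made for them only; others in the source may bear on it.

Measured compounds: compound 1 `FC(F)(F)c1cccc(NC(=S)Nc2ccc(I)cc2)c1` with 9500 nM and compound 2 `FC(F)(F)c1cccc(NC(=S)Nc2ccc(Cl)cc2)c1` with 11000 nM.

In an ADME assay on Vero 76 cells (Chlorocebus sabaeus) for cytotoxicity, read by crystal violet staining, with a stated time of 96 h (a higher number here means that more compound is tolerated, a lower number that less compound is tolerated), compound 2 gives 11000 nM, the highest of the two numbers, though its step from compound 1 is within the scatter. Compound 3 `N#Cc1ccc(NC(=S)Nc2cccc(C(F)(F)F)c2)cc1` is obtained from compound 2 by cyano in place of chloro on an aromatic carbon. Going by the values given here, the only measured step, a 1.2-fold higher number from compound 1 to compound 2 (0.06 log units; within the scatter), exchanges one halogen for another and bears on this change only loosely. No step beyond the scatter is therefore expected; compound 3 is estimated at 12000 nM, between 5000 nM and 30000 nM, a step of a 1.1-fold higher number from compound 2 to compound 3 (0.04 log units; within the scatter).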

Compound 3, half-maximal cytotoxic concentration: 10000 nM
For compound 3 the middle estimate is 1.2-fold (0.08 log units) above the measured one; low and high end bracket the measured number.
By their numbers in this assay, from the lowest: compounds 1, 3 and 2 (each within the scatter of the next).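

In this assay, cyano takes the place of a halogen at this position, para to a large group, and the number stays within the scatter: there is a 1.1-fold lower number from compound 2 to compound 3 (0.04 log units; within the scatter) and a 1.1-fold higher number from compound 1 to compound 3 (0.02 log units; within the scatter). Chloro, iodo and cyano are therefore not told apart here, although cyano brings a hydrogen-bond acceptor and a triple bond. Nothing available gives a reason for this. On these data alone, whether an amine or a carboxylic acid at this position would also stay within the scatter remains open. So does the role of the trifluoromethyl group, which all three compounds share.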